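Shortening the Hydroxyalkynyl Chain on the Shared Core

A few compounds are considered here, and "the series" means these few. Any claim that something is new, unique, unknown or untested is made for them only; others in the source may bear on it.

Compound 1, `OCC#CCSc1cnc2ccccc2c1SCC#CCCl`, is the starting point. In a functional assay on CCRF-CEM cells (Homo sapiens) for antiproliferative activity, with a stated time of 72 h (a higher number here means a weaker inhibitor, a lower number a stronger inhibitor), compound 1 gives 3.3 ug/mL. Among the three measured compounds it holds the second highest number, and both neighbours sit within the usual scatter of it. Compound 2, `OCC#CCSc1cnc2ccccc2c1[Se]CC#CCCl`, gives 2.6 ug/mL, and the step is a 1.3-fold lower number from compound 1 to compound 2 (0.10 log units; within the scatter). Compound 3, `OCC#CCSc1cnc2ccccc2c1Cl`, gives 4.1 ug/mL, with a 1.2-fold higher number from compound 1 to compound 3 (0.09 log units; within the scatter). The remaining pair, from compound 2 to compound 3, shows a 1.6-fold higher number from compound 2 to compound 3 (0.20 log units; within the scatter).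

Compound 4 is `CSc1cnc2ccccc2c1SCC#CCCl`. The change from compound 1 is hydrogen in place of 3-hydroxyprop-1-yn-1-yl on a saturated chain carbon bound to a sulfur. For the measured compounds named here, none of the measured steps touches this position: each of them alters a group on an aromatic carbon, and every one of them stays inside the scatter. Going by the values given here, those steps therefore say only that the core has tolerated sizeable replacements without a clear shift, and they give no direct reading on the chain that is removed here. The expectation is thus no step beyond the scatter.

For compound 4 the estimate in this assay is 3.5 ug/mL, expected to fall between 1.7 ug/mL and 7.5 ug/mL. Against compound 1 the step expected is a 1.1-fold higher number from compound 1 to compound 4 (0.03 log units; within the scatter).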

Compound 4, concentration for 50% inhibition: 2.5 ug/mL
Compound 4: the middle estimate sits 1.4-fold (0.15 log units) above what was measured; low and high end bracket the measured number.
By their numbers in this assay, from the lowest: compounds 4, 2, 1 and 3 (each within the scatter of the next).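

For the compounds shown here, this is the first measured step at the saturated chain carbon bound to a sulfur, and in this assay hydrogen in place of 3-hydroxyprop-1-yn-1-yl gives a 1.3-fold lower number from compound 1 to compound 4 (0.12 log units; within the scatter). Read one bond further out, the 4-hydroxybut-2-yn-1-yl chain of compound 1 is cut back to the methyl of compound 4, and the triple bond and the hydrogen-bond donor and acceptor of the departing group go with it, yet the number stays within the usual scatter, so in this assay on these cells the activity of compound 1 does not depend measurably on that group. No other measurement shown bears on this result, so it stands as an observation without an explanation.

The compounds shown give only these two groups at this place, so it remains open whether a carboxylic acid, an amine or a longer chain such as hexyl would also leave the number within the scatter. On these data alone, it is also open whether the same change would read the same way on compound 2, which carries selenium in its other chain.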